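This account rests on a few compounds, and the source may have more. Where it says the series, first, only, none or still open, it means among the compounds named here.

Measured compounds:
compound 1 `CCO[C@@]1(CC)CCC2(CO1)[C@@H]1CCC3=C4[C@@H](CC3=O)[C@H](C(=O)OC)C[C@@]42CN(C)C1` gives > 40000 nM in a functional assay on SMMC-7721 cells (Homo sapiens) for cytotoxicity, read by MTT assay, with a stated time of 48 h; a higher number here means a weaker inhibitor, a lower number a stronger inhibitor.
compound 2 `CC[C@]1(OC)CCC2(CO1)[C@@H]1CCC3=C4[C@H](CC3=O)[C@H](C(=O)OC)C[C@@]42CN(C)C1` gives > 40000 nM in this assay.

Compound 1 stands only at a limit of this assay: no number is known for it, just the sign that the assay reached its ceiling. The same holds for compound 2, whose value is also a limit. Going by the values given here, both sit at the limit of > 40000 nM in this assay, at which 2 of the 2 values shown sit, so no step between measured compounds can be drawn.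

Compound 3 `CC[C@]1(OC)CCC2(CO1)[C@@H]1CCC3=C4[C@@H](CC3=O)[C@H](C(=O)OC)C[C@@]42CN(C)C1` has not been measured. It differs from compound 1 by hydrogen in place of methyl on a saturated chain carbon bound to an oxygen on a saturated carbon. A change as small as hydrogen in place of methyl on a saturated chain carbon bound to an oxygen on a saturated carbon gives no reason, from what is known of compound 1, to expect a move beyond the ordinary scatter in this assay. Compound 3 is therefore expected to give 40000 nM, within 20000 nM to 80000 nM, an expected step of a number no higher from compound 1 to compound 3 (the limit leaves the size open) that most likely ends again at a limit.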

Compound 3, half-maximal inhibitory concentration: > 40000 nM
Compound 3: only a limit was reported (the forecaster's own chance of this, stated with the estimate: 85%); the middle value sits exactly at the limit.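

No step can be read from compound 1 to compound 3 or from compound 2 to compound 3, as all three compounds stand at a limit and not at a number: the limit of > 40000 nM in this assay, at which 3 of the 3 values shown sit.

Left open is whether going from ethoxy to methoxy, or the stereocentre that differs between compound 2 and compound 3, changes the result at all.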